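Swapping Benzyloxy for Ethoxy on a Weak Inhibitor

The source may report more compounds than this note shows. Statements on the series, on what has been measured and on what is new or still open speak of the compounds shown alone.

Compound 2 `c1ccc(COc2ccc(OCCOCCNC3CCCC3)cc2)cc1` gives 24800 nM in a functional assay on SK-OV-3 cells (Homo sapiens) for inhibition, read by CCK-8 assay, with a stated time of 70 h (on this read-out higher numbers stand for weaker inhibition and lower numbers for stronger inhibition), the lower of the two numbers measured, though compound 1 `COc1cc(OCCOCCNC2CCCC2)ccc1OCc1ccccc1` at 44600 nM lies within the scatter of it, and the step of a 1.8-fold lower number from compound 1 to compound 2 (0.25 log units; within the scatter) is correspondingly small. Compound 3 `CCOc1ccc(OCCOCCNC2CCCC2)cc1` differs from compound 2 by methyl in place of phenyl on a saturated chain carbon bound to an oxygen on an aromatic ring. Among the compounds with values here, no measured step touches this part of the molecule, so only the size of the single known step guides the expectation: a small change, in no clear direction. Compound 3 is therefore expected to give 30000 nM (range 12000 nM to 75000 nM), a step of a 1.2-fold higher number from compound 2 to compound 3 (0.08 log units; within the scatter) estimated to stay within the scatter.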

Compound 3, half-maximal inhibitory concentration: 90500 nM
For compound 3 the middle estimate is 3.0-fold (0.48 log units) below the measured one; the whole stated range lies below it.
By their numbers in this assay, from the lowest: compounds 2 and 1 (each within the scatter of the next); then compound 3.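

Changing benzyloxy to ethoxy gives, in this assay, a 3.6-fold higher number from compound 2 to compound 3 (0.56 log units; beyond the scatter), so inhibition weakens when methyl takes the place of phenyl at this position. Unlike the earlier methoxy step, which stayed within the scatter, this change moves the number beyond it, making this the first position shown to matter in these compounds. No available evidence explains the loss.

On these data alone, it remains open whether a propyl chain would hold the number of compound 2 or whether a ring is needed. A pyridylmethyl or chlorobenzyl group at this position also remains untested in the compounds shown.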